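Same Chlorine Swap Tried on a Rearranged Core

This account rests on a few compounds, and the source may have more. Where it says the series, first, only, none or still open, it means among the compounds named here.

Compound 1 `Cc1ccc(C(=O)NNC(=O)c2ccc(NS(=O)(=O)c3cnc(O)nc3O)cc2)cc1` reaches only a limit of the assay in a functional assay on MDA-MB-231 cells (Homo sapiens) for antiproliferative activity, read by MTT assay, with a stated time of 24 h (on this read-out higher numbers stand for weaker inhibition and lower numbers for stronger inhibition), giving > 20000 nM. Compound 2 `O=C(NNC(=O)c1ccccc1Cl)c1ccc(NS(=O)(=O)c2cnc(O)nc2O)cc1` gives 13900 nM in this assay. The change between them, (2-chlorophenyl in place of 4-methylphenyl on a carbonyl carbon), produced an at least 1.4-fold lower number from compound 1 to compound 2 (0.15 log units; that floor lies within the scatter). Compound 3 `Cc1ccc(C(=O)NNC(=O)c2ccccc2NS(=O)(=O)c2cnc(O)nc2O)cc1` holds the same atoms as compound 1 joined differently; the difference between the two cores is not broken down here. In this assay compound 3 again reaches only a limit, giving > 20000 nM. Compound 4 `O=C(NNC(=O)c1ccccc1NS(=O)(=O)c1cnc(O)nc1O)c1ccccc1Cl` carries the same change, (2-chlorophenyl in place of 4-methylphenyl on a carbonyl carbon), onto the core of compound 3. Going by the values given here, because of the limit of > 20000 nM in this assay, at which 2 of the 3 values shown sit, a firm reading for compound 4 is uncertain, and the small step seen from compound 1 to compound 2 is the only guide. The step is expected to be an at least 1.1-fold lower number from compound 3 to compound 4 (0.04 log units; that floor lies within the scatter). Compound 4 is therefore estimated at 18000 nM, between 8000 nM and 40000 nM.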

Compound 4, half-maximal inhibitory concentration: 8310 nM
For compound 4 the middle estimate is 2.2-fold (0.34 log units) above the measured one; the measured number falls inside the stated range.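

In this assay, 2-chlorophenyl in place of 4-methylphenyl on a carbonyl carbon gave an at least 2.4-fold lower number from compound 3 to compound 4 (0.38 log units; beyond the scatter), so on this second core the change produces a step that clears the usual scatter. This does not show that the change does more on one core than on the other: the same change on two cores in this assay, an at least 1.4-fold lower number (0.15 log units; that floor lies within the scatter) from compound 1 to compound 2 and an at least 2.4-fold lower number (0.38 log units; beyond the scatter) from compound 3 to compound 4; the limit leaves it open whether they differ. Both steps start from a limit, which makes each a floor and not a full size, and two cores cannot establish how the change behaves across the series: the limit of > 20000 nM in this assay, at which 2 of the 4 values shown sit.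

On these data alone, it remains open whether a carboxylic acid or a longer chain in place of the 2-chlorophenyl would lower the number further. The pairs also cannot separate the gain of chlorine from the loss of the methyl.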